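The compounds below may be only part of what the source reports. "The series", "measured", "known", "first", "only" and "open" are said of these compounds alone.

Measured compounds in a toxicity assay on THP-1 cells (Homo sapiens) for inhibition; on this read-out higher numbers stand for lower toxicity in this test and lower numbers for higher toxicity in this test:
compound 1 `Cn1c(-c2cccc(Cl)c2)cnc1NC(=O)c1ccc(F)cc1`: > 50000 nM
compound 2 `COc1ccc(-c2cnc(NC(=O)c3ccco3)n2C)cc1`: > 100000 nM

Compound 1 gives > 50000 nM in this assay, which is a limit of the assay and not a number; it stands at the limit of > 50000 nM in this assay, at which 1 of the 2 values shown sits. Compound 2 gives > 100000 nM in this assay, again a limit rather than a number, at the limit of > 100000 nM in this assay, at which 1 of the 2 values shown sits. Among the compounds with values here, compound 2 thus stands at the upper limit of what this assay reports, and of the two values shown both are limits, so no step between measured compounds can be sized.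

Compound 3 `CCCC(=O)Nc1ncc(-c2ccc(OC)cc2)n1C` is not yet measured. It differs from compound 2 by propyl in place of furan-2-yl on a carbonyl carbon. Within the data shown here, no measured step covers this change, so no direction can be read from the series. The step from compound 2 to compound 3 is expected to be a number no higher from compound 2 to compound 3 (the limit leaves the size open), that is, none beyond the scatter. For compound 3 the expected value in this assay is 100000 nM, within 30000 nM to 300000 nM, most likely reported again as a limit.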

Compound 3, half-maximal cytotoxic concentration: > 100000 nM
Compound 3: a limit, no number (the forecaster's own chance of this, stated with the estimate: 80%); the middle value sits exactly at the limit.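

Compound 2 and compound 3 both stand at a limit of the assay and not at a number, so no step between them can be read: the limit of > 100000 nM in this assay, at which 2 of the 3 values shown sit.

The compounds shown leave open whether propyl in place of furan-2-yl on a carbonyl carbon changes toxicity in this assay at all.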